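A few compounds are considered here, and "the series" means these few. Any claim that something is new, unique, unknown or untested is made for them only; others in the source may bear on it.

Measured so far in a functional assay on DLD-1 cells (Homo sapiens) for antiproliferative activity, read by CellTiter-Glo, with a stated time of 72 h; a lower number here means a stronger inhibitor, a higher number a weaker inhibitor:
- compound 1, `CC1CCN(C2CCN(S(=O)(=O)c3ccc(F)cc3F)CC2)CC1`: 102 nM
- compound 2, `Cc1nc(Cl)sc1S(=O)(=O)N1CCC(N2CCC(C)CC2)CC1`: 1.6 nM
- compound 3, `CC1CCN(C2CCN(S(=O)(=O)c3ccc(Cl)cc3Cl)CC2)CC1`: 1 nM

Compound 3 gives the lowest number of the three, but its gap to compound 2 is within the scatter, so the two are not separated; only compound 1 stands clearly apart, a 100-fold lower number from compound 1 to compound 3 (2.01 log units; beyond the scatter) and a 64-fold lower number from compound 1 to compound 2 (1.80 log units; beyond the scatter). The one place that varies across these three is the group on the sulfonyl sulfur, and the swap of halogens there, a 1.6-fold lower number from compound 2 to compound 3 (0.20 log units; within the scatter) aside, is where all the movement in this assay has come from.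

Compound 4, `CC1CCN(C2CCN(S(=O)(=O)c3cccc(Cl)c3)CC2)CC1`, changes the same place: 3-chlorophenyl in place of 2,4-dichlorophenyl on a sulfonyl sulfur. Within the data shown here, no measured step removes a chlorine from this ring or moves one; the measured steps only show that the identity of the ring on the sulfonyl sulfur can shift the number by a large amount. Since one of the two chlorines that carried compound 3 to its low value is lost, a step upward beyond the scatter is expected, though smaller than the gap between compound 1 and compound 3. The expected step is a 15-fold higher number from compound 3 to compound 4 (1.18 log units; beyond the scatter). Compound 4 is estimated at 15 nM, with a range from 3 nM to 80 nM.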

Compound 4, half-maximal inhibitory concentration: > 5000 nM
Compound 4 was reported as a limit; the forecaster's own chance of this, stated with the estimate: 2%; at least 330-fold (2.52 log units) between middle value and limit.
By their numbers in this assay, from the lowest: compounds 3 and 2 (each within the scatter of the next); then compound 1. At a limit, above all of these: compound 4.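

In this assay, compound 4 has no numerical value, only a limit: the limit of > 5000 nM in this assay, at which 1 of the 4 values shown sits.

Even taken as minimum sizes, the steps are large: an at least 5000-fold higher number from compound 3 to compound 4 (3.69 log units; beyond the scatter), an at least 3100-fold higher number from compound 2 to compound 4 (3.49 log units; beyond the scatter) and an at least 49-fold higher number from compound 1 to compound 4 (1.69 log units; beyond the scatter). The earlier compounds shown here showed that the group on the sulfonyl sulfur could move the number, but all of them stayed measurable; this change shows that 3-chlorophenyl in place of 2,4-dichlorophenyl can take the series past the limit of this assay, and that the presence of a chlorine on the ring does not by itself secure a low number. The step also goes beyond the one from the 2,4-difluorophenyl of compound 1, so among these four compounds the 3-chlorophenyl group gives the highest reading, although its true size remains unknown.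

This single change both removes one chlorine and leaves the other in a different pattern from compound 3, so the two effects cannot be separated; 2-chlorophenyl and 4-chlorophenyl groups on the sulfonyl sulfur would be needed to do so. Going by these compounds, it also remains open whether a methyl, methoxy or nitrile group could stand in for either chlorine of compound 3.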